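The compounds below may be only part of what the source reports. "The series", "measured", "known", "first", "only" and "open" are said of these compounds alone.

Three esters of the same pyrazine acid have been tested on cells, and the series is built around compound 2 `COc1ccc(/C=C/C(=O)O)cc1OC(=O)c1nc(C)c(C)nc1C`. In a functional assay on EA.hy 926 cells (Homo sapiens) for cytotoxicity, read by MTT assay, with stated times of 24 h and 12 h, tested at 100 uM (on this read-out higher numbers stand for a stronger effect at the one concentration tested and lower numbers for a weaker effect), compound 2 gives 216%, the highest of the three numbers. Within the data shown here, its nearest neighbour is compound 3 `CCOC(=O)/C=C/c1ccc(OC)c(OC(=O)c2nc(C)c(C)nc2C)c1`, which gives 117% in this assay; the only single-point step among the measured compounds runs from compound 2 to compound 3, and it is a number 99 percentage points lower from compound 2 to compound 3 (beyond the scatter). Compound 1 `COc1ccc(OC(=O)c2nc(C)c(C)nc2C)c(/C=C/C(=O)O)c1`, which carries its groups in a different arrangement, gives 79.2% in this assay and lies furthest from compound 2.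

The next compound, compound 4 `Cc1nc(C)c(C(=O)Oc2cccc(/C=C/C(=O)O)c2)nc1C`, differs from compound 2 in one place: hydrogen in place of methoxy on an aromatic carbon. Among the measured compounds shown here, no measured step touches this position, so nothing among the three compounds speaks directly to the loss of the methoxy group. For the measured compounds named here, the one measured step, from compound 2 to compound 3, shows that a single small change elsewhere in the molecule moved this read-out by a large amount, and both other compounds sit well below compound 2. On this basis a drop is expected, though its size is uncertain. For compound 4 the estimate in this assay is 140%, within 70% to 220%, which would mean an expected step of a number 76 percentage points lower from compound 2 to compound 4 (beyond the scatter).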

Compound 4, a percentage reported as activity, at one concentration (the size of the read-out at that concentration, not a potency): 103%
For compound 4 the middle estimate is 37 percentage points above the measured one; the range from low to high includes it.
By their numbers in this assay, from the lowest: compound 1; then compound 4; then compound 3; then compound 2.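

In this assay the change to hydrogen in place of methoxy, on an aromatic carbon ortho to a large group and para to a 2-carboxyethenyl group, gives a number 113 percentage points lower from compound 2 to compound 4 (beyond the scatter) and counts as a large step. Compounds 1, 2 and 3 all carry the methoxy group, so none of them could show what its loss does; this step shows that the read-out of compound 2 depends on this position and does not survive the removal of the group intact. Compound 2 now has two single-place changes on record, the second being ethyl in place of hydrogen on an oxygen next to a carbonyl group with a number 99 percentage points lower from compound 2 to compound 3 (beyond the scatter) as its result, and both lead to a lower number, beyond the scatter.

Going by these compounds, how an ethoxy group, a hydroxyl group or a chlorine atom on the same aromatic carbon would read remains open, as does whether losing the methoxy group would matter equally in the ethyl ester or in the arrangement of compound 1. Nothing given here explains why the number falls when the methoxy group leaves.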